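Bromo to Trifluoromethyl: An Expected Potency for Compound 4

This account rests on a few compounds, and the source may have more. Where it says the series, first, only, none or still open, it means among the compounds named here.

Measured so far in a functional assay (trachea) with Rattus norvegicus as the target; a higher number here means a more potent compound, by a factor of ten per unit of this negative logarithm, a lower number a less potent compound:
Compound 1 `CC(=O)c1ccc2c(c1)C(n1ccccc1=O)=CC(C)(C)O2` gives 6.65.
Compound 2 `CC1(C)C=C(n2ccccc2=O)c2cc(C=C(C#N)C#N)ccc2O1` gives 6.3.
Compound 3 `CC1(C)C=C(n2ccccc2=O)c2cc(Br)ccc2O1` gives 7.53.

Compound 3 stands highest of the three, beyond the scatter in both comparisons: a number 0.88 log units higher from compound 1 to compound 3 (beyond the scatter) and a number 1.23 log units higher from compound 2 to compound 3 (beyond the scatter). Compound 4 `CC1(C)C=C(n2ccccc2=O)c2cc(C(F)(F)F)ccc2O1` differs from compound 3 at one place only: trifluoromethyl in place of bromo on an aromatic carbon. Among the measured compounds shown here, no measured step involves trifluoromethyl, so the two steps into compound 3 bear only indirectly; they show that changing the group at this position moves the numbers by modest to large amounts. With nothing to show which way trifluoromethyl falls, a small step at most is expected, a number 0.23 log units lower from compound 3 to compound 4 (within the scatter). Compound 4 is therefore estimated to give 7.3, within a range from 6.7 to 7.9.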

Compound 4, logarithm of the reciprocal of the active concentration, log(1/C): 7.37
The estimate for compound 4 lay 0.07 log units below the measured number; low and high end bracket the measured number.
By their numbers in this assay, from the lowest: compound 2; then compound 1; then compounds 4 and 3 (each within the scatter of the next).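

With a number 0.16 log units lower from compound 3 to compound 4 (within the scatter) the data do not separate trifluoromethyl from bromo at this position, although trifluoromethyl brings more heavy atoms. The steps of a number 1.07 log units higher from compound 2 to compound 4 (beyond the scatter) and a number 0.72 log units higher from compound 1 to compound 4 (beyond the scatter) show that trifluoromethyl, like bromo, gives a higher number than both 2,2-dicyanoethenyl and acetyl here, so this level is no longer tied to bromo alone.

From the compounds shown here alone, how an amine, a carboxylic acid or a longer chain would fare at this position stays open. Nothing available explains why trifluoromethyl and bromo give such similar numbers.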